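The source may report more compounds than this note shows. Statements on the series, on what has been measured and on what is new or still open speak of the compounds shown alone.

Values in a functional assay on blood (Homo sapiens), with a stated time of 60 min, in the presence of a further agent that is not named here; on this read-out lower numbers stand for an effect already at smaller amounts and higher numbers for an effect only at larger amounts of compound:
- compound 1 `O=C(O)C1(S(=O)(=O)c2ccc(Oc3ccc(OC(F)(F)F)cc3)cc2)CCC2(CCNCC2)C1`: 1800 nM
- compound 2 `COC(=O)C1(S(=O)(=O)c2ccc(Oc3ccc(OC(F)(F)F)cc3)cc2)CCC2(CCNCC2)C1`: > 15000 nM
- compound 3 `O=C(Nc1ccccc1O)C1(S(=O)(=O)c2ccc(Oc3ccc(OC(F)(F)F)cc3)cc2)CCC2(CCNCC2)C1`: > 15000 nM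

Compound 3 gives only a limit, > 15000 nM, and not a number. Compound 2 also gives only a limit, > 15000 nM. Compound 4 `COc1ccc(N)c(NC(=O)C2(S(=O)(=O)c3ccc(Oc4ccc(OC(F)(F)F)cc4)cc3)CCC3(CCNCC3)C2)c1` carries 2-amino-5-methoxyphenyl in place of 2-hydroxyphenyl on an amide-type nitrogen. Going by the values given here, no measured step changes this group. The nearest changes are at the carbonyl carbon of compound 1, with an at least 8.3-fold higher number from compound 1 to compound 3 (0.92 log units; beyond the scatter) and an at least 8.3-fold higher number from compound 1 to compound 2 (0.92 log units; beyond the scatter), both beyond the scatter. Compound 4 keeps the amide of compound 3, so no clear gain is expected in this assay, and no step beyond the scatter in either direction. The expected step is a number no higher from compound 3 to compound 4 (the limit leaves the size open). For compound 4 the estimate is 15000 nM, with an expected range of 3000 nM to 50000 nM.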

Compound 4, half-maximal effective concentration: 3700 nM
For compound 4 the middle estimate is 4.1-fold (0.61 log units) above the measured one; low and high end bracket the measured number.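

In this assay, the group on the amide-type nitrogen matters: 2-amino-5-methoxyphenyl in place of 2-hydroxyphenyl gives an at least 4.0-fold lower number from compound 3 to compound 4 (0.60 log units; beyond the scatter), so the amide alone does not fix a value at the limit. (2-Amino-5-methoxyphenyl)amino in place of methoxy on the carbonyl carbon gives an at least 4.0-fold lower number from compound 2 to compound 4 (0.60 log units; beyond the scatter), and this step also starts from a limit. In place of hydroxy, the same group gives a 2.1-fold higher number from compound 1 to compound 4 (0.31 log units; beyond the scatter), so the amide does not match the carboxylic acid here.

The step between compound 2 and compound 3 cannot be read: the limit of > 15000 nM in this assay, at which 2 of the 4 values shown sit. Also open, going by these compounds, is whether the amino group or the methoxy carries the gain, and a plain 2-aminophenyl on the same nitrogen would separate the two.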